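Fluoro on the phenyl sulfonyl: expected effect on maximal response

The source may report more compounds than this note shows. Statements on the series, on what has been measured and on what is new or still open speak of the compounds shown alone.

Compound 1 `CN1CCC(n2cc(S(=O)(=O)c3cccc(F)c3)c3cccnc32)C1` gives 54%.
Compound 2 `O=S(=O)(c1ccccc1)c1cn(C2CCCNC2)c2ncccc12` gives 56%.

Going by the values given here, in a functional assay on HeLa cells for agonist activity at 5-hydroxytryptamine receptor 6 (Homo sapiens), read by cAMP accumulation and immunoassay (on this read-out lower numbers stand for smaller maximal responses and higher numbers for larger maximal responses), compound 2 stands highest of the two numbers measured so far, and its nearest neighbour is compound 1, whose value lies within the scatter of that of compound 2. The next compound is compound 3 `O=S(=O)(c1cccc(F)c1)c1cn(C2CCCNC2)c2ncccc12`, which differs from compound 2 only by fluoro in place of hydrogen on an aromatic carbon. Since compound 1 already carries a fluoro and gives 54%, no step beyond the scatter is expected from compound 2 to compound 3 in this assay, with a number 1 percentage points lower from compound 2 to compound 3 (within the scatter). Compound 3 is therefore estimated at 55%, within the range 43% to 67%.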

Compound 3, largest response reached (Emax), in percent of the reference or control that the assay uses: 84%
Compound 3: middle estimate off by 29 percentage points, on the low side; the whole stated range lies below it.
By their numbers in this assay, from the lowest: compounds 1 and 2 (each within the scatter of the next); then compound 3.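

In this assay, the change from phenyl to 3-fluorophenyl gives a number 28 percentage points higher from compound 2 to compound 3 (beyond the scatter), so this one aromatic carbon can shift the maximal response. With the 3-fluorophenyl kept, piperidin-3-yl in place of 1-methylpyrrolidin-3-yl on the aromatic nitrogen gives a number 30 percentage points higher from compound 1 to compound 3 (beyond the scatter), so the group on that nitrogen matters as well. No measurement available here accounts for either step. As far as these compounds go, whether chloro, methoxy or a nitrile in place of the fluoro would give a similar response remains open. Also open, from the compounds shown here alone, is whether the fluoro step would hold with 1-methylpyrrolidin-3-yl on the nitrogen.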